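Swapping the Pyridine Substituent: Compound 3 to Compound 4

The source may hold more compounds than are shown below. What is called first, only, known or untested is meant among the compounds shown, and "the series" means these compounds.

The measured compounds are these:
Compound 1 `N#Cc1ccc(NC(=O)c2ccc(-c3ncccc3C(F)(F)F)cc2)cc1`, which in a functional assay for antagonist activity at transient receptor potential cation channel subfamily V member 1 (Rattus norvegicus) (on this read-out higher numbers stand for weaker inhibition and lower numbers for stronger inhibition), gives 1300 nM.
Compound 2 `Cc1cccnc1-c1ccc(C(=O)Nc2ccc(C(F)(F)F)cc2)cc1`, which in this assay gives 81 nM.
Compound 3 `CC(C)(C)c1ccc(NC(=O)c2ccc(-c3ncccc3NC3CCCC3)cc2)cc1`, which in this assay gives 44 nM.

All three share a core in which an amide links two aromatic rings, with a pyridine attached to one of them. Compound 3 shows the lowest number of the three in this assay, but its gap to compound 2 lies within the scatter, so those two cannot be told apart. Compound 1, which carries a nitrile and a trifluoromethyl-bearing pyridine, sits clearly higher and is the only one of the three that stands apart beyond the scatter.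

Compound 4 `CN(C)Cc1cccnc1-c1ccc(C(=O)Nc2ccc(C(C)(C)C)cc2)cc1` is not yet measured. It keeps everything of compound 3 except the group on the pyridine: (dimethylamino)methyl in place of cyclopentylamino on an aromatic carbon. The new group has no ring and no hydrogen-bond donor, and it sits two atoms from the ring nitrogen, ortho to a large group, just as the old one did.

Among the measured compounds shown here, no directly comparable step has been measured, so there is no anchor for this change. Compound 2 shows that a small group at that position can still give a low number, which suggests the change need not cost much. Compound 4 is therefore expected to give a modest rise at most, a 2.3-fold higher number from compound 3 to compound 4 (0.36 log units; beyond the scatter), possibly within the scatter. The estimate for compound 4 is 100 nM, with a range from 30 nM to 400 nM.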

Compound 4, half-maximal inhibitory concentration: 234 nM
Estimate against measurement, compound 4: 2.3-fold (0.37 log units) below; the range from low to high includes it.
By their numbers in this assay, from the lowest: compounds 3 and 2 (each within the scatter of the next); then compound 4; then compound 1.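

Among the compounds shown here, this is the first change at this position measured with the rest of the molecule held fixed. In this assay, (dimethylamino)methyl in place of cyclopentylamino on an aromatic carbon of the six-membered aromatic ring with 1 nitrogen gives a 5.3-fold higher number from compound 3 to compound 4 (0.73 log units; beyond the scatter) and so shows that the position responds to the group placed there, even though both groups carry 1 hydrogen-bond acceptor. Several things change together in this one step, including the ring, the hydrogen-bond donor and the number of heavy atoms, and nothing measured on these compounds says why the number rises.

Still open, on these data alone, is which of these differences carries the step: isopropylamino on the same carbon would keep a hydrogen-bond donor without a ring, while cyclopentyloxy would keep the ring without a donor. Also open, as far as these compounds go, is whether a step of this size would carry over to the other end of the molecule as found in compound 2, which differs from compound 3 in more than one place and so cannot be compared with it directly.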